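The compounds below may be only part of what the source reports. "The series", "measured", "known", "first", "only" and "open" are said of these compounds alone.

Measured in an ADME assay on HEK293 cells (Homo sapiens) for cytotoxicity, with a stated time of 72 h (a lower number here means that less compound is needed, a higher number that more compound is needed for the effect), so far:
compound 1 `COc1ccc(-c2nc3ccccc3o2)cc1NC(=O)c1cc([N+](=O)[O-])ccc1Cl` gives > 25000 nM
compound 2 `O=C(Nc1ccc(F)c(-c2nc3ccccc3s2)c1)c1cc([N+](=O)[O-])ccc1Cl` gives > 25000 nM
compound 3 `O=C(Nc1cccc(-c2nc3ccccc3s2)c1)c1cc([N+](=O)[O-])ccc1Cl` gives > 27000 nM

All three entries are limits, so compound 3 has no number and no rank in the series. Compound 4 `COc1ccc(-c2nc3ccccc3s2)cc1NC(=O)c1cc([N+](=O)[O-])ccc1Cl` carries methoxy in place of hydrogen on an aromatic carbon, methoxy in place of hydrogen on an aromatic carbon, ortho to a large group and para to a 1,3-benzothiazol-2-yl group. Going by the values given here, the only measured step, a step that the two limits leave unreadable from compound 2 to compound 3, gives no size to go on. Compound 1 also carries methoxy and gives > 25000 nM as a limit. No step beyond the scatter is therefore expected in this assay, and no direction can be named. The expected outcome is an at least 1.0-fold lower number from compound 3 to compound 4 (0.03 log units; that floor lies within the scatter). For compound 4 the estimate is 25000 nM, with an expected range from 13000 nM to 50000 nM.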

Compound 4, half-maximal effective concentration: > 25000 nM
Compound 4 was reported as a limit; the forecaster's own chance of this, stated with the estimate: 88%; the middle value lies on the limit itself.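

In this assay compound 4 gives > 25000 nM, which is a limit. Going by these compounds alone, no step to compound 4 from compound 1 or compound 3 can therefore be read. The compounds shown leave open whether methoxy or the 1,3-benzothiazol-2-yl group changes the result in this assay at all.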